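Compound 4: piperazinyl replacing aminoamino on a shared core

The source may report more compounds than this note shows. Statements on the series, on what has been measured and on what is new or still open speak of the compounds shown alone.

The three measured compounds, all read in a functional assay on U-937 cells (Homo sapiens) for cytotoxicity, read by MTT assay, with a stated time of 3 days (a lower number here means a stronger inhibitor, a higher number a weaker inhibitor), are:

compound 1, `N#Cc1c(NN)nc(SCc2nc3ccccc3[nH]2)nc1-c1ccccc1`, which gives 3.9 nM;
compound 2, `N#Cc1c(Nc2nccs2)nc(SCc2nc3ccccc3[nH]2)nc1-c1ccccc1`, which gives 3.8 nM;
compound 3, `N#Cc1c(NNC(N)=S)nc(SCc2nc3ccccc3[nH]2)nc1-c1ccccc1`, which gives 3 nM.

Compound 1 carries the highest of the three numbers, yet every other compound lies within the scatter of it: the step of a 1.0-fold lower number from compound 1 to compound 2 (0.01 log units; within the scatter) and the step of a 1.3-fold lower number from compound 1 to compound 3 (0.11 log units; within the scatter) both stay inside the usual spread of repeated measurements, as does the step of a 1.3-fold lower number from compound 2 to compound 3 (0.10 log units; within the scatter) between the other two. Nothing among these three therefore separates one compound from another.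

Compound 4, `N#Cc1c(-c2ccccc2)nc(SCc2nc3ccccc3[nH]2)nc1N1CCNCC1`, has not yet been measured. It differs from compound 1 in that (piperazin-1-yl in place of aminoamino on an aromatic carbon). The measured steps bear on it only indirectly: both a 1.0-fold lower number from compound 1 to compound 2 (0.01 log units; within the scatter) and a 1.3-fold lower number from compound 1 to compound 3 (0.11 log units; within the scatter) change what sits on the amine nitrogen of the aminoamino group and leave the number unmoved, whereas compound 4 removes that group altogether and sets a ring in its place on the aromatic carbon. Among the measured compounds shown here, no measured pair shows such an exchange. The author therefore expects no step beyond the scatter, with a wider range than usual, and estimates a 1.3-fold higher number from compound 1 to compound 4 (0.11 log units; within the scatter) for compound 4. The estimate for compound 4 is 5 nM, with a range from 1.5 nM to 18 nM.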

Compound 4, half-maximal inhibitory concentration: 5.81 nM
For compound 4 the middle estimate is 1.2-fold (0.07 log units) below the measured one, and the stated range covers the measured number.
By their numbers in this assay, from the lowest: compounds 3, 2, 1 and 4 (each within the scatter of the next).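

In this assay, the aromatic carbon next to the ring nitrogen and ortho to a cyano group accepts more than a change on the amine nitrogen of the aminoamino group: the whole group can give way to piperazin-1-yl, a six-membered non-aromatic ring, with a 1.5-fold higher number from compound 1 to compound 4 (0.17 log units; within the scatter). The same exchange read against the other two substituents gives a 1.5-fold higher number from compound 2 to compound 4 (0.18 log units; within the scatter) and a 1.9-fold higher number from compound 3 to compound 4 (0.29 log units; within the scatter), so piperazin-1-yl stands within the scatter of the aminoamino, (1,3-thiazol-2-yl)amino and thiosemicarbazide-type groups alike. These open-chain and aromatic groups and this non-aromatic ring therefore cannot be told apart at this position in this assay, and no separate measurement is at hand that would account for this result.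

From the compounds shown here alone, whether morpholin-4-yl or a carboxylic acid on this aromatic carbon would also stay within the scatter remains open, as does the effect of an acetyl group on the piperazin-1-yl ring. The phenyl group is the same in all four compounds, so what a methyl group in its place would do is equally unknown.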